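Removing a fluoro from the aryl ring: an expected step

The source may report more compounds than this note shows. Statements on the series, on what has been measured and on what is new or still open speak of the compounds shown alone.

Compound 1 `Cc1nc(-c2ccccc2)c(C(=O)N2CCN(c3cccc(Cl)c3)CC2)o1` gives 39.2 nM in a functional assay on HL-60 cells (Homo sapiens) for inhibition, read by MTT assay, with a stated time of 72 h; on this read-out lower numbers stand for stronger inhibition and higher numbers for weaker inhibition.
Compound 2 `Cc1nc(-c2cccc(F)c2)c(C(=O)N2CCN(c3cccc(Cl)c3)CC2)o1` gives 33.7 nM in this assay.
Compound 3 `COc1cccc(N2CCN(C(=O)c3oc(C)nc3-c3ccc(F)cc3)CC2)c1` gives 112 nM in this assay.

Compound 3 carries the highest number of the three; its nearest neighbour is compound 1 and its furthest is compound 2, both beyond the scatter. How the core of compound 3 differs from that of compound 2 is not broken down here.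

Compound 4 `COc1cccc(N2CCN(C(=O)c3oc(C)nc3-c3ccccc3)CC2)c1` is compound 3 with one change: hydrogen in place of fluoro on an aromatic carbon. The same kind of change leads from compound 2 to compound 1: hydrogen in place of fluoro on an aromatic carbon. The surroundings differ, though: in compound 2 the fluoro sits meta to a large group, in compound 3 para to a large group. That earlier step was a 1.2-fold higher number from compound 2 to compound 1 (0.07 log units; within the scatter).

Because a 1.2-fold higher number from compound 2 to compound 1 (0.07 log units; within the scatter) stays within the scatter, a similarly small step is expected here, a 1.1-fold higher number from compound 3 to compound 4 (0.05 log units; within the scatter). Compound 4 is therefore estimated at 125 nM, most likely between 55 nM and 280 nM in this assay.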

Compound 4, half-maximal inhibitory concentration: 34.8 nM
Beside the measured number, compound 4's estimate is 3.6-fold (0.56 log units) above it, outside the stated range (below it).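

In this assay, replacing 4-fluorophenyl with phenyl gives a 3.2-fold lower number from compound 3 to compound 4 (0.51 log units; beyond the scatter), so this change does not carry over unchanged from one core to the other: the same change on two cores in this assay, a 1.2-fold higher number (0.07 log units; within the scatter) from compound 2 to compound 1 and a 3.2-fold lower number (0.51 log units; beyond the scatter) from compound 3 to compound 4, 3.7-fold (0.57 log units) apart, beyond the scatter of two such steps. Once the fluoro is gone, the two cores read alike, with methoxy in place of chloro giving only a 1.1-fold lower number from compound 1 to compound 4 (0.05 log units; within the scatter). This does not show why the step differs, since the two fluoro compounds differ both in where the fluoro sits and in carrying methoxy or chloro, and two pairs cannot separate these.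

The compounds shown leave open which of those two differences matters. They also leave open how a nitrile or an amine in the fluoro's place would behave on either core.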